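A few compounds are considered here, and "the series" means these few. Any claim that something is new, unique, unknown or untested is made for them only; others in the source may bear on it.

Compound 1 `CC(Nc1ncnc2ccc(-c3cnn(C4CCNCC4)c3)cc12)c1c(Cl)ccc(F)c1Cl`, 8130 nM; compound 2 `c1cnc2ccc(Nc3ncnc4ccc(-c5cnn(C6CCNCC6)c5)cc34)cc2c1`, 12900 nM; compound 3 `COc1cccc(CNc2ncnc3ncc(-c4cnn(C)c4)cc23)c1`, > 100000 nM.

In a functional assay on BT-474 cells (Homo sapiens) for antiproliferative activity, read by MTT assay, with a stated time of 72 h (a lower number here means a stronger inhibitor, a higher number a weaker inhibitor), compound 1 gives 8130 nM. Among the measured compounds shown here, the single measured step runs a 1.6-fold higher number from compound 1 to compound 2 (0.20 log units; within the scatter). Compound 2, at 12900 nM, thus has the higher of the two numbers, but sits within the scatter of compound 1. Compound 3 gives only a limit in this assay, > 100000 nM (the limit of > 100000 nM in this assay, at which 1 of the 3 values shown sits).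

Compound 4 `Cn1cc(-c2ccc3ncnc(Nc4ccc5ncccc5c4)c3c2)cn1` differs from compound 2 by methyl in place of piperidin-4-yl on an aromatic nitrogen. No measured step changes this position, so nothing shown gives the size of the step. The change expected from compound 2 to compound 4 is a 2.3-fold higher number from compound 2 to compound 4 (0.37 log units; beyond the scatter). Compound 4 is estimated at 30000 nM, between 8000 nM and 100000 nM.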

Compound 4, half-maximal inhibitory concentration: 10900 nM
Compound 4: the middle estimate sits 2.8-fold (0.44 log units) above what was measured; measured number inside the range.
By their numbers in this assay, from the lowest: compounds 1, 4 and 2 (each within the scatter of the next). At a limit, above all of these: compound 3.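

Methyl in place of piperidin-4-yl on the aromatic nitrogen gives a 1.2-fold lower number from compound 2 to compound 4 (0.07 log units; within the scatter) in this assay, the first measured step at this position. With the quinolin-6-yl group held, compound 2 and compound 4 cannot be told apart, so the six-membered non-aromatic ring can give way to a single carbon with no change beyond the scatter.

From the compounds shown here alone, whether a longer chain, an amine or a carboxylic acid on this nitrogen would separate from these values stays open. Nothing shown bears on this step or offers a cause for it.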